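A few compounds are considered here, and "the series" means these few. Any claim that something is new, unique, unknown or untested is made for them only; others in the source may bear on it.

Compound 1, `Cc1ccc(-c2cnn3c(NCc4ccccn4)cc(C)nc23)cc1`, is the starting point of this step. In a physicochemical assay for solubility, read by HPLC, using the shake flask method, measured as kinetic solubility, with a stated time of 2 h, at pH 7.4 (a lower number here means a less soluble compound, a higher number a more soluble compound), compound 1 gives < 5000 nM, which is a limit of the assay rather than a number. the limit of < 5000 nM in this assay, at which 2 of the 3 values shown sit, marks the floor against which two of the three measured compounds are reported. Compound 2, `Cc1cc(NCc2cnccn2)n2nc(C)c(-c3ccccc3)c2n1`, gives 7100 nM in this assay. Compound 3, `Cc1cc(NCc2ncc[nH]2)n2nc(C)c(-c3ccccc3)c2n1`, gives < 5000 nM in this assay, again a limit. For the measured compounds named here, the only step measured between two compounds that differ in one place is an at least 1.4-fold lower number from compound 2 to compound 3 (0.15 log units; that floor lies within the scatter), and that change concerns the group on the saturated chain carbon bound to the ring nitrogen, not the aromatic carbon changed here.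

Compound 4, `Cc1cc(NCc2ccccn2)n2ncc(-c3ccco3)c2n1`, differs from compound 1 by furan-2-yl in place of 4-methylphenyl on an aromatic carbon. Going by the values given here, no measured step addresses this exchange, so the measured data give no direction for it, and the limit at which compound 1 sits leaves its actual number unknown. Compound 4 is therefore expected to land near the same floor, with the step of a number no lower from compound 1 to compound 4 (the limit leaves the size open) estimated as no change beyond the scatter. In this assay compound 4 is estimated at 5000 nM, within a range from 2000 nM to 15000 nM.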

Compound 4, solubility: 48800 nM
The estimate for compound 4 lay 9.8-fold (0.99 log units) below the measured number; measured number above the stated range.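

At this aromatic carbon of a five-membered aromatic ring with 2 nitrogen, furan-2-yl in place of 4-methylphenyl gives an at least 9.7-fold higher number from compound 1 to compound 4 (0.98 log units; beyond the scatter) in this assay. For the compounds shown here, this exchange therefore provides the first step that is printed as beyond the scatter, and it shows that this position can move the read-out, whereas the only earlier step concerned the group on the saturated chain carbon and had a floor within the scatter. From the compounds shown here alone, compound 1 stands at a limit of the assay rather than at a number, and because of this the step is only a floor and its full size stays unknown: the limit of < 5000 nM in this assay, at which 2 of the 4 values shown sit.

The exchange replaces a six-membered aromatic ring of carbon only with a five-membered aromatic ring with 1 hetero atom and also removes the methyl group, so the compounds shown cannot separate the contribution of the oxygen, the ring size or the methyl group. Going by these compounds, it also remains open whether thiophen-2-yl, with sulfur in place of the oxygen, or an unsubstituted phenyl ring at this carbon would give a similar result.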